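This account rests on a few compounds, and the source may have more. Where it says the series, first, only, none or still open, it means among the compounds named here.

Measured compounds:
compound 1 `CNc1nc(Nc2ccc(C)c(N)c2)ncc1C(=O)Nc1cc(NC(=O)c2cccc(C(F)(F)F)c2)ccc1C` gives > 10000 nM
compound 2 `CNc1nc(Nc2ccc(C)c([N+](=O)[O-])c2)ncc1C(=O)Nc1cc(NC(=O)c2ccccc2OC)ccc1C` gives > 10000 nM
compound 3 `CNc1nc(Nc2ccc(C)c([N+](=O)[O-])c2)ncc1C(=O)Nc1cc(NC(=O)c2ccc(OC)c(OC)c2)ccc1C` gives 7300 nM

In an ADME assay on BaF3 cells (Mus musculus) for antiproliferative activity, read by CellTiter-Glo and CCK-8 assay, with a stated time of 72 h (on this read-out lower numbers stand for stronger inhibition of growth and higher numbers for weaker inhibition of growth), compound 2 reaches only a limit of the assay, > 10000 nM. Compound 1 likewise gives only a limit, > 10000 nM. Going by the values given here, the one numbered value belongs to compound 3, which in this assay gives 7300 nM, so that the step of an at least 1.3-fold lower number from compound 2 to compound 3 (0.13 log units; that floor lies within the scatter) is a floor rather than a measured distance; its relevance is restated by the limit of > 10000 nM in this assay, at which 2 of the 3 values shown sit.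

Compound 4 `CNc1nc(Nc2ccc(C)c(N)c2)ncc1C(=O)Nc1cc(NC(=O)c2ccccc2OC)ccc1C` differs from compound 2 by amino in place of nitro on an aromatic carbon. Among the compounds with values here, no measured pair among compounds 1, 2 and 3 isolates this change, since compound 1 carries the amino group but also a different acyl group, and the step from compound 2 to compound 3 alters only the acyl group. The two compounds bearing the nitro or the amino group on this ring both sit at the limit, which gives no ground for expecting a move beyond the scatter. Compound 4 is therefore expected at 15000 nM, between 6000 nM and 40000 nM, and the expected step from compound 2 is a step that the limit leaves unreadable from compound 2 to compound 4, most probably again reported only as a limit.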

Compound 4, concentration for 50% growth inhibition: > 10000 nM
Compound 4: no number, only a limit; the forecaster's own chance of this, stated with the estimate: 70%; the middle value lies beyond the limit too.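

Compound 4 gives only a limit, as do compound 1 and compound 2, so the steps from compound 1 and compound 2 to compound 4 cannot be read: the limit of > 10000 nM in this assay, at which 3 of the 4 values shown sit. The compounds shown leave open whether amino in place of nitro on an aromatic carbon changes growth inhibition at all.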